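Does a second methoxy shift growth inhibition?

A few compounds are considered here, and "the series" means these few. Any claim that something is new, unique, unknown or untested is made for them only; others in the source may bear on it.

Values in a functional assay on DWD cells (Homo sapiens) for inhibition, read by sulforhodamine B assay; on this read-out lower numbers stand for stronger inhibition of growth and higher numbers for weaker inhibition of growth:
- Compound 1 `COc1ccc(-c2ccc(-c3ccc(-c4nc5c(O)cccc5[nH]4)cc3)cc2)cc1`: 6400 nM
- Compound 2 `CN(C)c1ccc(-c2ccc(-c3ccc(-c4nc5c(O)cccc5[nH]4)cc3)cc2)cc1`: 9210 nM
- Compound 3 `COc1ccc(-c2ccc(-c3ccc(-c4nc5c(O)cccc5[nH]4)cc3)cc2)cc1OC`: not yet measured

For the measured compounds named here, only two numbers are available so far, and they cannot be told apart. Going by the values given here, the single measured step, a 1.4-fold higher number from compound 1 to compound 2 (0.16 log units; within the scatter), puts dimethylamino in place of methoxy on an aromatic carbon. Among the compounds with values here, compound 2 therefore stands level with its only neighbour.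

The next change is 3,4-dimethoxyphenyl in place of 4-(dimethylamino)phenyl on an aromatic carbon. Compound 3 thus returns to methoxy, as in compound 1 at 6400 nM, and carries one more of that group. Within the data shown here, no measured step tests that extra methoxy, so the range must stay wide. No step beyond the scatter is expected in this assay. The expected step is a 1.3-fold lower number from compound 2 to compound 3 (0.12 log units; within the scatter). The estimate for compound 3 is 7000 nM, with an expected range of 3000 nM to 16000 nM.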

Compound 3, concentration for 50% growth inhibition: 1400 nM
Compound 3: the middle estimate sits 5.0-fold (0.70 log units) above what was measured; measured number outside the range, below it.
By their numbers in this assay, from the lowest: compound 3; then compounds 1 and 2 (each within the scatter of the next).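

Changing dimethylamino to methoxy had shifted nothing beyond the scatter, so this end of the molecule looked insensitive, yet in this assay adding a second methoxy in place of hydrogen on an aromatic carbon gives a 4.6-fold lower number from compound 1 to compound 3 (0.66 log units; beyond the scatter) and shows that growth inhibition can respond to a change here. The larger swap of 4-(dimethylamino)phenyl for 3,4-dimethoxyphenyl gives a 6.6-fold lower number from compound 2 to compound 3 (0.82 log units; beyond the scatter) and points the same way, though the gain remains modest. Nothing measured here explains this gain.

From the compounds shown here alone, it remains open whether the gain depends on methoxy itself or whether another group on that carbon, such as ethoxy, hydroxyl or fluorine, would give a similar number. A third methoxy on the same ring is also untested among the compounds shown.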